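The source may report more compounds than this note shows. Statements on the series, on what has been measured and on what is new or still open speak of the compounds shown alone.

Three compounds with a shared core built around a methylpyrrolidine linked through an oxygen to an aromatic ring were measured in an assay on membranes from Cerebral cortex for displacement of a labelled ligand from Neuronal acetylcholine receptor; alpha4/beta2 (Rattus norvegicus), with a stated time of 30 min; on this read-out higher numbers stand for weaker inhibition and lower numbers for stronger inhibition. Compound 1, `CN1CCC[C@H]1COc1cccc(C#CCCCCO)c1`, gives 4400 nM in this assay. Compound 2, `CN1CCC[C@H]1COc1cc(O)cc(C#CCCCCO)c1`, gives 23.7 nM. The two differ by hydroxy in place of hydrogen on an aromatic carbon, and this change brought a 190-fold lower number from compound 1 to compound 2 (2.27 log units; beyond the scatter).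

Compound 3, `CN1CCC[C@H]1COc1cc(-c2ccccc2)cc([N+](=O)[O-])c1`, belongs to a second series whose core carries a nitro group and a phenyl ring; how its core differs from that of compound 1 is not broken down here. In this assay compound 3 gives 330 nM, which places it between the other two measured compounds.

Compound 4, `CN1CCC[C@H]1COc1cc(-c2ccc(O)cc2)cc([N+](=O)[O-])c1`, has not yet been measured. It differs from compound 3 by hydroxy in place of hydrogen on an aromatic carbon. This is the same kind of change as that from compound 1 to compound 2, but not the same: in the earlier pair the hydroxy entered on the central ring, meta to a 6-hydroxyhex-1-yn-1-yl group and meta to a group of 8 heavy atoms, whereas in compound 4 it enters on the outer ring, para to a large group.

Since the surroundings differ, the earlier gain is only a loose guide. Compound 4 is therefore expected to show a step of a 3.3-fold lower number from compound 3 to compound 4 (0.52 log units; beyond the scatter) in this assay, smaller than the earlier one. The estimate for compound 4 is 100 nM, with a plausible span from 15 nM to 500 nM.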

Compound 4, inhibition constant: 12 nM
Estimate against measurement, compound 4: 8.3-fold (0.92 log units) above; the whole stated range lies above it.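

In this assay, putting a hydroxy in place of a hydrogen on the outer ring, which turns phenyl into 4-hydroxyphenyl, gives a 28-fold lower number from compound 3 to compound 4 (1.44 log units; beyond the scatter), so the number also falls on this second core, with the hydroxy para to a large group. Among the compounds shown here, the direction of the change carried over from one core to the other, but its size did not, and the gap between the two steps is larger than repeat measurements alone would produce: the same change on two cores in this assay, a 190-fold lower number (2.27 log units; beyond the scatter) from compound 1 to compound 2 and a 28-fold lower number (1.44 log units; beyond the scatter) from compound 3 to compound 4, 6.8-fold (0.83 log units) apart, beyond the scatter of two such steps With only two pairs, this does not show whether the gap comes from the core or from the ring that carries the hydroxy, as the two pairs differ in both, so it gives no rule for the size of the step on a further core.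

The compounds shown leave open whether a methoxy group or an amine in the same place on the outer ring would lower the number as the hydroxy does. They also leave open how large the step would be with the hydroxy on the central ring of the core of compound 3, or with a nitrile in place of its nitro group.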